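Swapping a Pyrazine for a Pyridine in a Diaryl Urea

The source may hold more compounds than are shown below. What is called first, only, known or untested is meant among the compounds shown, and "the series" means these compounds.

Three ureas have been measured in an ADME assay on microsomes from liver (Mus musculus) for metabolic stability, using NADPH, with a stated time of 60 min; on this read-out lower numbers stand for slow clearance and higher numbers for fast clearance. Compound 1, `N#Cc1ccc(NC(=O)Nc2ccnc(C(F)(F)F)c2)cc1`, sits at the limit of this assay, < 7 uL/min, which is a boundary rather than a number. Compound 2, `N#Cc1ccc(NC(=O)Nc2ccc(F)c(C(F)(F)F)c2)cc1`, gives 12 uL/min. Compound 3, `O=C(Nc1ccc(F)c(C(F)(F)F)c1)Nc1cnccn1`, gives 160 uL/min, the highest of the two numbers shown, standing well beyond the scatter above compound 2. The limit at which compound 1 sits is the limit of < 7 uL/min in this assay, at which 1 of the 3 values shown sits.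

Compound 4, `O=C(Nc1ccncc1)Nc1ccc(F)c(C(F)(F)F)c1`, has not been measured in this assay. It differs from compound 3 in one place: pyridin-4-yl in place of pyrazin-2-yl on an amide-type nitrogen. Going by the values given here, no measured pair shows this exact change, so its effect has to be guessed from the surrounding compounds; compound 1 also carries a pyridin-4-yl ring and sits at the limit, but its other half differs from that of compound 4, so the comparison is indirect. A step down in this assay is expected, moderate in size, a 2.0-fold lower number from compound 3 to compound 4 (0.30 log units; within the scatter). Compound 4 is thus expected to fall near 80 uL/min, within a range from 25 uL/min to 250 uL/min.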

Compound 4, intrinsic clearance in a liver preparation (reported as CLH), per the amount of preparation that the assay uses in the Mus musculus assay: 37 uL/min
Estimate against measurement, compound 4: 2.2-fold (0.33 log units) above; measured number inside the range.
By their numbers in the Mus musculus assay, from the lowest: compound 2; then compound 4; then compound 3. At a limit, below all of these: compound 1.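

Going by these compounds alone, this is the first comparison in which only one place changes: pyridin-4-yl in place of pyrazin-2-yl on an amide-type nitrogen gives, in the Mus musculus assay, a 4.3-fold lower number from compound 3 to compound 4 (0.64 log units; beyond the scatter). In a physicochemical assay for solubility, read by nephelometry, in phosphate buffer, measured as kinetic solubility, at pH 6.5 (on this read-out higher numbers stand for higher solubility and lower numbers for lower solubility), compound 3 gives < 1.6 ug/mL, which is a limit of the assay and not a number. Within the data shown here, in the physicochemical assay compound 4 gives 6.3 ug/mL, so in this one pair the single change goes with slower clearance and higher solubility together, with no trade-off between the two read-outs.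

As far as these compounds go, whether the same swap acts alike on other ureas, such as those carrying the nitrile-bearing half, remains open, since this is a single pair. Also open, from the compounds shown here alone, is how the pyridin-4-yl ring would respond to an added group, such as an amine or a methoxy group.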